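Ethoxy on two related cores in a rat inhibition assay

The source may report more compounds than this note shows. Statements on the series, on what has been measured and on what is new or still open speak of the compounds shown alone.

Compound 1 `COc1cccc(-c2ncc(C(=O)O)c(=O)[nH]2)c1` and compound 2 `CCOc1ccc(OC)cc1-c1ncc(C(=O)O)c(=O)[nH]1` share one core, and compound 2 differs from compound 1 by ethoxy in place of hydrogen on an aromatic carbon. In a functional assay on the whole organism (strain Sprague-Dawley) for inhibition, with Rattus norvegicus as the target, with a stated time of 10 min (a lower number here means that less compound is needed, a higher number that more compound is needed for the effect), compound 1 gives 10 mg/kg, whereas compound 2 gives 0.2 mg/kg, a step of a 50-fold lower number from compound 1 to compound 2 (1.70 log units; beyond the scatter). Compound 3 `Cn1c(-c2ccccc2)ncc(C(=O)O)c1=O` has a different core; how the two cores differ is not broken down here. In this assay compound 3 gives 50 mg/kg, the highest of the three numbers. Compound 4 `CCOc1ccccc1-c1ncc(C(=O)O)c(=O)n1C` differs from compound 3 by ethoxy in place of hydrogen on an aromatic carbon, the same kind of change, though here the place is ortho to a large group only and not also para to a methoxy group. A step of a 10-fold lower number from compound 3 to compound 4 (1.00 log units; beyond the scatter) is expected, resting on the step of a 50-fold lower number from compound 1 to compound 2 (1.70 log units; beyond the scatter) but tempered, since the surroundings of the place differ. Compound 4 is thus estimated at 5 mg/kg, expected between 1.5 mg/kg and 20 mg/kg.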

Compound 4, dose for 50% inhibition: > 50 mg/kg
Compound 4 was reported as a limit (the forecaster's own chance of this, stated with the estimate: 5%); middle value at least 10-fold (1.00 log units) from the limit.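

In this assay compound 4 gives > 50 mg/kg, which is a limit of the assay and not a number. The data give a number no lower from compound 3 to compound 4 (the limit leaves the size open) and the ethoxy change did not carry over from one core to the other: the same change on two cores in this assay, a 50-fold lower number (1.70 log units; beyond the scatter) from compound 1 to compound 2 and a number no lower (the limit leaves the size open) from compound 3 to compound 4, at least 50-fold (1.69 log units) apart, beyond the scatter of two such steps. What this does not show is whether the core or the surroundings of the place decide the outcome, nor how far compound 4 lies past the limit: the limit of > 50 mg/kg in this assay, at which 1 of the 4 values shown sits.

The compounds shown leave open whether ethoxy would behave on the core of compound 3 as it does on the core of compound 1 if a methoxy group were also on the ring. Also open, as far as these compounds go, is how a propoxy chain or an amine would behave in the same place.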